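Hydroxymethyl in Place of Hydroxy on an Amide Chain

This account rests on a few compounds, and the source may have more. Where it says the series, first, only, none or still open, it means among the compounds named here.

Of the compounds shown here, three have so far been measured in an assay on CHO cells for displacement of a labelled ligand from adenosine receptor A1 (Homo sapiens), read by scintillation counting, with a stated time of 60 min, tested at 10 uM; a higher number here means more inhibition at the concentration tested (going by the name of the read-out), a lower number less inhibition. Compound 1 `O=C(NCC(O)CO)c1cc2cc(Cl)ccc2oc1=O` gives 21% in this assay. Compound 2 `COc1cccc2cc(C(=O)NC3CCCCC3)c(=N)oc12` gives 40% in this assay. Compound 3 `N=c1oc2ccc(Br)cc2cc1C(=O)NCCO` gives 26% in this assay. Among these three numbers the value of compound 3 is the second highest; its nearest neighbour is compound 1, whose number lies within the usual scatter of repeated measurements, so compound 3 and compound 1 cannot be told apart on these data, while compound 2 stands beyond the scatter above compound 3.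

Compound 4 `N=c1oc2ccc(Br)cc2cc1C(=O)NCCCO` has not yet been measured. It differs from compound 3 in one place: hydroxymethyl in place of hydroxy on a saturated chain carbon, two bonds along the chain from an amide-type nitrogen. Among the measured compounds shown here, no pair of measured compounds differs by a single change, so no measured step gives a direct anchor for the size of this one. With only the chain on the amide lengthened, a step from compound 3 to compound 4 of the size a number 2 percentage points higher from compound 3 to compound 4 (within the scatter) is expected, that is, none beyond the scatter in either direction. Compound 4 is therefore estimated to give 28% in this assay, with a range from 12% to 45%.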

Compound 4, a percentage reported as inhibition, at one concentration (the size of the read-out at that concentration, not a potency): 32%
For compound 4 the middle estimate is 4 percentage points below the measured one; the range from low to high includes it.
By their numbers in this assay, from the lowest: compounds 1, 3, 4 and 2 (each within the scatter of the next, the first and the last beyond it).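

In this assay, among the compounds shown here, the exchange of hydroxy for hydroxymethyl on a saturated chain carbon, two bonds along the chain from an amide-type nitrogen, gives a number 6 percentage points higher from compound 3 to compound 4 (within the scatter) and so provides the first measured step in this set that isolates a single place. The earlier compounds shown here differed in several places at once and could say nothing about this chain alone, whereas this pair shows that going from 2-hydroxyethyl to 3-hydroxypropyl on the amide, with the hydrogen-bond donor and acceptor counts of the exchanged groups unchanged, does not separate the two compounds at the single concentration tested. Nothing measured here speaks to why the step has this size.

From the compounds shown here alone, it remains open whether a longer chain such as 4-hydroxybutyl, or an amine or a carboxylic acid at the end of the chain in place of hydroxy, would move the number beyond the scatter. One step on one core also leaves open whether the same lengthening would read alike on the core of compound 1 or of compound 2.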